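This account rests on a few compounds, and the source may have more. Where it says the series, first, only, none or still open, it means among the compounds named here.

Values in a functional assay on the whole organism with Mus musculus as the target (on this read-out higher numbers stand for an effect only at larger amounts of compound and lower numbers for an effect already at smaller amounts), for the compounds measured so far

compound 1 `CN1C(=O)CCC1(O)c1cccc(C(F)(F)F)c1` gives 93.8 mg/kg
compound 2 `O=C(CCC(=O)c1cccc(C(F)(F)F)c1)NC1CCCCC1` gives > 200 mg/kg
compound 3 `CN1C(=O)CCC1(O)c1cccc(Cl)c1` gives 158 mg/kg

The entry for compound 2 (> 200 mg/kg) is a limit of the assay and not a number. Within the data shown here, compound 3 (158 mg/kg) sits within the scatter of compound 1, the only other compound with a real number here.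

Compound 4 `Cc1cccc(C2(O)CCC(=O)N2C)c1` has not been measured yet. It differs from compound 3 by carrying methyl in place of chloro on an aromatic carbon.

Among the measured compounds shown here, only one measured step resembles this swap, namely chloro in place of trifluoromethyl on an aromatic carbon, and it stayed within the scatter (a 1.7-fold higher number from compound 1 to compound 3 (0.23 log units; within the scatter)). One step is thin support, but it gives no reason to look for a large shift. No change beyond the scatter is therefore expected in this assay, and the expected step is small (a 1.0-fold higher number from compound 3 to compound 4 (0.01 log units; within the scatter)). For compound 4 the estimated value is 160 mg/kg with an expected range from 85 mg/kg to 300 mg/kg.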

Compound 4, dose for half-maximal effect: 81.5 mg/kg
Compound 4: middle estimate off by 2.0-fold (0.29 log units), on the high side, and the stated range ends above it.
By their numbers in this assay, from the lowest: compounds 4, 1 and 3 (each within the scatter of the next). At a limit, above all of these: compound 2.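

In this assay, methyl in place of chloro on the aromatic carbon gives a step within the scatter (a 1.9-fold lower number from compound 3 to compound 4 (0.29 log units; within the scatter)), and methyl in place of trifluoromethyl does the same (a 1.2-fold lower number from compound 1 to compound 4 (0.06 log units; within the scatter)). Earlier, only chloro and trifluoromethyl could be compared at this place; now three groups have been tried on the shared core, and this read-out does not separate any of them. No information at hand bears on why these three groups give values so close together.

The compounds shown leave open whether a group of another kind at this place, such as an amine, a carboxylic acid or a longer chain, would move the number beyond the scatter. They also leave open whether methyl, chloro or trifluoromethyl would behave alike on another carbon of the same ring.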